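From a Cyanophenyl to a Chlorophenyl Sulfonamide

This account rests on a few compounds, and the source may have more. Where it says the series, first, only, none or still open, it means among the compounds named here.

Compound 1 `CC1CCN(C2CCN(S(=O)(=O)c3cccc(-c4ccccc4C(F)(F)F)c3)CC2)CC1` gives > 5000 nM in an ADME assay on HCT-116 cells (Homo sapiens) for cytotoxicity, read by CellTiter-Glo, with a stated time of 72 h; on this read-out higher numbers stand for weaker inhibition and lower numbers for stronger inhibition.
Compound 2 `Cc1nc(Cl)sc1S(=O)(=O)N1CCC(N2CCC(C)CC2)CC1` gives > 10000 nM in this assay.
Compound 3 `CC1CCN(C2CCN(S(=O)(=O)c3ccc(C#N)cc3)CC2)CC1` gives > 5000 nM in this assay.

Compound 3 stands at a limit of this assay rather than at a number, the one described by the limit of > 5000 nM in this assay, at which 2 of the 3 values shown sit. Compound 2 likewise stands at a limit, that of the limit of > 10000 nM in this assay, at which 1 of the 3 values shown sits. For that reason the step that the two limits leave unreadable from compound 2 to compound 3 cannot be read. Among the measured compounds shown here, no measured step is therefore readable, and none bears on the change to compound 4 `CC1CCN(C2CCN(S(=O)(=O)c3cccc(Cl)c3)CC2)CC1`, which is 3-chlorophenyl in place of 4-cyanophenyl on a sulfonyl sulfur. With every value in the set sitting at a limit, nothing points to a step beyond the scatter in either direction, and the expected step that the limit leaves unreadable from compound 3 to compound 4 is estimated to be small. Compound 4 is therefore expected to give 8000 nM in this assay, within a range from 3000 nM to 30000 nM, most likely again reported only as a limit.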

Compound 4, half-maximal inhibitory concentration: > 5000 nM
Compound 4 ended at the assay's limit; the forecaster's own chance of this, stated with the estimate: 80%; the middle value does not contradict the limit.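

In this assay compound 4 gives > 5000 nM, which is a limit and not a number. The steps to compound 4 from compound 1, compound 2 and compound 3 cannot be read. The compounds shown leave open how any of these four compounds truly compare in cytotoxicity.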